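Swapping a Chlorophenyl Group for Acetyl: Expected Cell Tolerance

The compounds below may be only part of what the source reports. "The series", "measured", "known", "first", "only" and "open" are said of these compounds alone.

Compound 1 `Cc1cccc(Cn2cc(CNC(=O)c3cnc(Nc4ccc(C#N)cc4)cc3Oc3c(C)cc(C)cc3C)nn2)c1` gives 114000 nM in an ADME assay on MT4 cells (Homo sapiens) for cytotoxicity, read by MTT assay, with a stated time of 5 days; a higher number here means that more compound is tolerated, a lower number that less compound is tolerated. Compound 2 `CCOC(=O)Cn1cc(CNC(=O)c2cnc(Nc3ccc(C#N)cc3)cc2Oc2c(C)cc(C)cc2C)nn1` gives 9530 nM. Compound 3 `Cc1cc(C)c(Oc2cc(Nc3ccc(C#N)cc3)ncc2C(=O)NCc2cn(Cc3ccccc3Cl)nn2)c(C)c1` gives >= 188000 nM, which is a limit of the assay rather than a number.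

Compound 3 therefore stands only at the limit of >= 188000 nM in this assay, at which 1 of the 3 values shown sits, so a floor is known for it and nothing more. Compound 4 `CC(=O)Cn1cc(CNC(=O)c2cnc(Nc3ccc(C#N)cc3)cc2Oc2c(C)cc(C)cc2C)nn1` differs from it in one place: acetyl in place of 2-chlorophenyl on a saturated chain carbon bound to an aromatic nitrogen. Going by the values given here, two measured steps bear on this. Going the other way, from a small ester group to the chlorophenyl group, gave an at least 19-fold higher number from compound 2 to compound 3 (1.29 log units; beyond the scatter). Replacing a methylphenyl group by that same ester group gave a 12-fold lower number from compound 1 to compound 2 (1.08 log units; beyond the scatter), so a small carbonyl-bearing chain in this position has gone with a clearly lower number than an aromatic ring both times. Acetyl is another small carbonyl-bearing chain, so a large drop in this assay is expected. The expected step is an at least 12-fold lower number from compound 3 to compound 4 (1.09 log units; beyond the scatter). Compound 4 is estimated at 15000 nM, with a range from 5000 nM to 60000 nM.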

Compound 4, half-maximal cytotoxic concentration: 19400 nM
The estimate for compound 4 lay 1.3-fold (0.11 log units) below the measured number; measured number inside the range.
By their numbers in this assay, from the lowest: compound 2; then compound 4; then compound 1. At a limit, above all of these: compound 3.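

In this assay, a second small carbonyl-bearing chain on a saturated chain carbon bound to an aromatic nitrogen again gives a lower number than the aromatic rings: an at least 9.6-fold lower number from compound 3 to compound 4 (0.98 log units; beyond the scatter), and a 5.9-fold lower number from compound 1 to compound 4 (0.77 log units; beyond the scatter). Compound 3 sits at a limit rather than a number, so the first of these steps is only a floor: the limit of >= 188000 nM in this assay, at which 1 of the 4 values shown sits.

Methyl in place of ethoxy on a carbonyl carbon gives a 2.0-fold higher number from compound 2 to compound 4 (0.31 log units; beyond the scatter), so what the carbonyl carries also shifts the number, and small carbonyl-bearing chains are not interchangeable here.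

Still open, going by these compounds, is whether the lower number goes with the carbonyl or simply with the loss of the aromatic ring; a plain butyl chain, with no carbonyl, would separate the two. On these data alone, how a chain carrying a carboxylic acid or an amine would read also remains open.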